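Swapping bromo for chloro on a low-inhibition paw-edema compound

This account rests on a few compounds, and the source may have more. Where it says the series, first, only, none or still open, it means among the compounds named here.

Measured so far:
Compound 1, `NS(=O)(=O)c1ccc2nc(N3N=C(c4ccc(Cl)cc4)CC3c3ccccc3)sc2c1`: 68.3%
Compound 2, `NS(=O)(=O)c1ccc2nc(N3N=C(c4ccc(Br)cc4)CC3c3cccs3)sc2c1`: 14%

Both compounds were tested in a functional assay on the whole organism (strain Wistar) for inhibition, with Rattus norvegicus as the target, read by paw edema, with stated times of 1 h and 5 h, at a dose of 20 mg/kg by the oral route; a higher number here means more inhibition at the dose given (going by the name of the read-out), a lower number less inhibition. Compound 1 gives 68.3%, while compound 2 gives 14%, the lowest of the two numbers and well beyond the usual scatter below compound 1. The two compounds differ in more than one place, so the two values alone do not tell which change drives the gap.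

Compound 3, `NS(=O)(=O)c1ccc2nc(N3N=C(c4ccc(Cl)cc4)CC3c3cccs3)sc2c1`, has not yet been measured. It differs from compound 2 in a single spot: chloro in place of bromo on an aromatic carbon. The halogen sits on an aromatic carbon of a six-membered aromatic ring of carbon only, the same spot in both compounds.

Because compound 2 gives 14%, and the change is limited to one halogen for another, the expected step in this assay is small, at most a modest rise that may not exceed the scatter. The step of a number 8 percentage points higher from compound 2 to compound 3 (within the scatter) is the estimated size of that move. Compound 3 is expected to give 22%, with a plausible range from 5% to 50%.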

Compound 3, a percentage reported as inhibition, in the whole organism at one dose (the size of the read-out at that dose, not a potency): 14%
Compound 3: the middle estimate sits 8 percentage points above what was measured, and the stated range covers the measured number.
By their numbers in this assay, from the lowest: compounds 2 and 3 (each within the scatter of the next); then compound 1.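

In this assay, chloro in place of bromo on the aromatic carbon gives no change at the digits printed from compound 2 to compound 3 (within the scatter), so with thiophen-2-yl on the saturated ring carbon, this exchange of one halogen for the other leaves the read-out where it was. Compound 1 and compound 3 both carry the 4-chlorophenyl group and differ in one place only, and thiophen-2-yl in place of phenyl on the saturated ring carbon gives a number 54.3 percentage points lower from compound 1 to compound 3 (beyond the scatter); the wide gap first seen between compound 1 and compound 2, which differ in two places, therefore appears in full across this single ring change, with the halogen held the same. Nothing measured here explains why this ring change goes with so large a step.

The compounds shown leave open whether bromo and chloro also match when phenyl sits on the saturated ring carbon, as the 4-bromophenyl group appears here only together with thiophen-2-yl. They also leave open what fluoro, a methoxy group or an amine would do in place of the halogen on the six-membered ring, and whether any such group could restore inhibition in the thiophen-2-yl series.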